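Amide nitrogen substituents in a phosphatase inhibitor series

The compounds below may be only part of what the source reports. "The series", "measured", "known", "first", "only" and "open" are said of these compounds alone.

Compound 1 `O=C(COc1ccc2cc(C(O)(C(F)(F)F)C(F)(F)F)c(O)cc2c1)Nc1nc2ccccc2s1` gives 10900 nM in an assay on isolated protein for inhibition of receptor-type tyrosine-protein phosphatase C (Homo sapiens), read by spectrophotometry; on this read-out higher numbers stand for weaker inhibition and lower numbers for stronger inhibition. Compound 2 `O=C(COc1ccc2cc(C(O)(C(F)(F)F)C(F)(F)F)c(O)cc2c1)Nc1ccccc1` returns > 20000 nM in this assay, which is a limit of the assay and not a number. Compound 3 `Oc1c(-c2ccccc2)cccc1C(O)(C(F)(F)F)C(F)(F)F` gives 157000 nM. Going by the values given here, the single recorded step on the amide nitrogen, an at least 1.8-fold higher number from compound 1 to compound 2 (0.26 log units; that floor lies within the scatter), rests on the limit of > 20000 nM in this assay, at which 1 of the 3 values shown sits, and stays within the scatter, so compound 2 stands at the limit with no resolved number.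

Compound 4 `COc1ccc(CNC(=O)COc2ccc3cc(C(O)(C(F)(F)F)C(F)(F)F)c(O)cc3c2)cc1OC` differs from compound 2 by 3,4-dimethoxybenzyl in place of phenyl on an amide-type nitrogen. Among the compounds with values here, no measured step covers a benzyl for phenyl exchange here; the only neighbouring step, an at least 1.8-fold higher number from compound 1 to compound 2 (0.26 log units; that floor lies within the scatter), is within the scatter. For compound 4 the expected step is therefore none beyond the scatter, a step that the limit leaves unreadable from compound 2 to compound 4. Compound 4 is estimated at 25000 nM, between 8000 nM and 80000 nM, with a real chance of again returning only a limit.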

Compound 4, half-maximal inhibitory concentration: > 20000 nM
Compound 4: only a limit was reported (the forecaster's own chance of this, stated with the estimate: 55%); the middle value lies beyond the limit too.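

Compound 4, with 3,4-dimethoxybenzyl on the amide-type nitrogen, also returns only a limit in this assay, so a benzyl-type group joins phenyl in giving no resolved number at this position. Set against 1,3-benzothiazol-2-yl, the change gives an at least 1.8-fold higher number from compound 1 to compound 4 (0.26 log units; that floor lies within the scatter), so no loss beyond the scatter is shown. The step between phenyl and 3,4-dimethoxybenzyl cannot be read: the limit of > 20000 nM in this assay, at which 2 of the 4 values shown sit.

Going by these compounds, whether any group on this nitrogen separates from compound 1 beyond the scatter stays open. On these data alone, how a carboxylic acid or an amine on a longer chain here would read in this assay also stays open.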